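Methoxy added on the fused ring of compound 1

The source may report more compounds than this note shows. Statements on the series, on what has been measured and on what is new or still open speak of the compounds shown alone.

Compound 1 `COc1cc(/C(Cl)=C/C=C(\C#N)C(=O)c2c[nH]c3ccccc23)cc(OC)c1OC` and compound 2 `COc1ccc(/C(Cl)=C/C=C(\C#N)C(=O)c2c[nH]c3ccccc23)cc1OC` have been tested in a functional assay for inhibition, read by Griess assay, with a stated time of 150 min, tested at 1 mM; a lower number here means less inhibition, a higher number more inhibition at the concentration tested (going by the name of the read-out). Within the data shown here, compound 1 gives 73.3%, numerically the lower of the two numbers so far; compound 2 gives 75%, and the step of a number 1.7 percentage points higher from compound 1 to compound 2 (within the scatter) lies within the scatter. Compound 3 `COc1ccc2[nH]cc(C(=O)/C(C#N)=C/C=C(\Cl)c3cc(OC)c(OC)c(OC)c3)c2c1` differs from compound 1 by methoxy in place of hydrogen on an aromatic carbon. Among the measured compounds shown here, the one measured step, a number 1.7 percentage points higher from compound 1 to compound 2 (within the scatter), also exchanges methoxy and hydrogen on an aromatic carbon and moved nothing beyond the scatter, so no step beyond the scatter is expected in this assay here either, a number 0.7 percentage points higher from compound 1 to compound 3 (within the scatter). Compound 3 is therefore estimated at 74%, within a range from 60% to 86%.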

Compound 3, a percentage reported as inhibition, at one concentration (the size of the read-out at that concentration, not a potency): 68.3%
Estimate against measurement, compound 3: 5.7 percentage points above; low and high end bracket the measured number.
By their numbers in this assay, from the lowest: compounds 3, 1 and 2 (each within the scatter of the next).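

In this assay methoxy in place of hydrogen on the six-membered aromatic ring of the fused system gives a number 5 percentage points lower from compound 1 to compound 3 (within the scatter) for this change. This ring, untouched by the earlier step, therefore accepts methoxy in this read-out without a change beyond the scatter at the single concentration tested. Nothing on hand bears on the reason for this result.

Going by these compounds, whether an amine or a carboxylic acid at this position would move the number beyond the scatter remains open. So does whether methoxy would leave the result unchanged at lower concentrations.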